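A few compounds are considered here, and "the series" means these few. Any claim that something is new, unique, unknown or untested is made for them only; others in the source may bear on it.

Measured compounds:
compound 1 `Cc1cc(F)cc(Nc2cc(NC(=O)Nc3c(Cl)cccc3Cl)ncn2)c1` – 49.1%
compound 2 `COc1ccc(Br)cc1Nc1cc(NC(=O)Nc2c(Cl)cccc2Cl)ncn1` – 53%

In a functional assay on HCC827 cells (Homo sapiens) for inhibition, read by MTT assay, with a stated time of 48 h, tested at 10 uM (a lower number here means less inhibition, a higher number more inhibition at the concentration tested (going by the name of the read-out)), compound 2 gives 53%, the higher of the two numbers, though only by a number 3.9 percentage points higher from compound 1 to compound 2 (within the scatter), a step that stays within the scatter. Compound 3 `COc1ccc(Nc2cc(NC(=O)Nc3c(Cl)cccc3Cl)ncn2)cc1C` is the next compound to be measured. Its structure differs from compound 2 in one place: 4-methoxy-3-methylphenyl in place of 5-bromo-2-methoxyphenyl on a nitrogen on an aromatic ring. Among the compounds with values here, the only step that bears on this change is the one on the same nitrogen, a number 3.9 percentage points higher from compound 1 to compound 2 (within the scatter), which shows that exchanging one substituted phenyl for another on that nitrogen changed the read-out little. Within the data shown here, no step with the 4-methoxy-3-methylphenyl group itself is available, so compound 3 is expected to stay close to compound 2, with a step of a number 3 percentage points lower from compound 2 to compound 3 (within the scatter) in this assay, not beyond the scatter. Compound 3 is therefore estimated at 50% in this assay, within a range from 30% to 70%.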

Compound 3, a percentage reported as inhibition, at one concentration (the size of the read-out at that concentration, not a potency): 63.1%
The estimate for compound 3 lay 13.1 percentage points below the measured number; the range from low to high includes it.
By their numbers in this assay, from the lowest: compounds 1 and 2 (each within the scatter of the next); then compound 3.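

In this assay, the group on this nitrogen now moves the read-out beyond the scatter, which the exchange between compound 1 and compound 2 had not done: 4-methoxy-3-methylphenyl gives a number 10.1 percentage points higher from compound 2 to compound 3 (beyond the scatter) and a number 14 percentage points higher from compound 1 to compound 3 (beyond the scatter). Both steps are modest, but they show that the read-out at this position does depend on which substituted phenyl is present, and that 4-methoxy-3-methylphenyl stands clear of the other two groups. No measurement at hand accounts for this difference.

The compounds shown leave open whether the methoxy or the methyl of 4-methoxy-3-methylphenyl carries the step, as the two enter together. They also leave open how the read-out would respond to an amine or a carboxylic acid on the phenyl, or to a longer chain in its place.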